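This account rests on a few compounds, and the source may have more. Where it says the series, first, only, none or still open, it means among the compounds named here.

Measured so far in a functional assay on SSMC-7721 cells (Homo sapiens) for antiproliferative activity, read by CCK-8 assay, with a stated time of 48 h; on this read-out higher numbers stand for weaker inhibition and lower numbers for stronger inhibition:
compound 1 `Cc1ccc(-c2nnc(-n3[se]c4ccccc4c3=O)s2)cc1` gives 16600 nM
compound 2 `O=c1c2ccccc2[se]n1-c1nnc(-c2ccc(Br)cc2)s1` gives 68200 nM
compound 3 `O=c1c2ccccc2[se]n1-c1nnc(-c2ccccc2Br)s1` gives 27400 nM

Compound 3 stands second highest of the three numbers in this assay. Its nearest neighbour is compound 1, and the gap between them is within the scatter; the step of a 2.5-fold lower number from compound 2 to compound 3 (0.40 log units; beyond the scatter) is the larger one, a modest difference beyond the scatter.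

Compound 4 `O=c1c2ccccc2[se]n1-c1nnc(-c2ccc(F)cc2)s1` is not yet measured. Relative to compound 3 the change is 4-fluorophenyl in place of 2-bromophenyl on an aromatic carbon. Going by the values given here, two measured steps bear on it. The step of a 2.5-fold lower number from compound 2 to compound 3 (0.40 log units; beyond the scatter) shows what moving bromine between the two phenyl positions did within this series. The step of a 4.1-fold higher number from compound 1 to compound 2 (0.61 log units; beyond the scatter) shows what exchanging methyl for bromo on the same aromatic carbon did. Among the compounds with values here, no measured pair isolates fluoro from bromo, so the size of that exchange is unknown here. Taken together, a 4-fluorophenyl compound would be expected to land somewhere between the numbers of compound 1 and compound 2, which brackets compound 3 on both sides; the expected step of a 1.1-fold higher number from compound 3 to compound 4 (0.04 log units; within the scatter) is therefore small, likely within the scatter, with the direction uncertain.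

For compound 4 in this assay the estimate is 30000 nM, in the range 10000 nM to 90000 nM.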

Compound 4, half-maximal inhibitory concentration: 42900 nM
Compound 4: middle estimate off by 1.4-fold (0.16 log units), on the low side; the range from low to high includes it.
By their numbers in this assay, from the lowest: compounds 1, 3, 4 and 2 (each within the scatter of the next, the first and the last beyond it).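

In this assay, going by these compounds alone, fluoro in place of bromo, an exchange no earlier pair isolated, gives a 1.6-fold lower number from compound 2 to compound 4 (0.20 log units; within the scatter), so the two halogens on the phenyl group are not told apart here. The change of 2-bromophenyl to 4-fluorophenyl gives a 1.6-fold higher number from compound 3 to compound 4 (0.19 log units; within the scatter), which also stays within the scatter, so this change of halogen and its place together has no resolved effect on the read-out. Fluoro in place of methyl gives a 2.6-fold higher number from compound 1 to compound 4 (0.41 log units; beyond the scatter), the same direction as a 4.1-fold higher number from compound 1 to compound 2 (0.61 log units; beyond the scatter), so among the 4-substituted phenyl compounds methyl stands apart from both halogens, although 2-bromophenyl goes against a clean split between methyl and halogen, with a 1.7-fold higher number from compound 1 to compound 3 (0.22 log units; within the scatter).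

No measurement at hand explains any of these steps. Still open, on these data alone, is whether 2-fluorophenyl would behave like 2-bromophenyl, and whether an amine, a methoxy group or a carboxylic acid on the phenyl group would move the number further from that of compound 1 or bring it lower.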